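Benzyl to Butyl on the Ring Carbamate

The compounds below may be only part of what the source reports. "The series", "measured", "known", "first", "only" and "open" are said of these compounds alone.

Compound 2 `Cc1cc(C)c(S(=O)(=O)N[C@@H](CNC(=O)C2=NO[C@]3(C2)C[C@@H](CNc2ncc[nH]2)N(C(=O)OCc2ccccc2)C3)C(=O)O)c(C)c1` is the stronger of the two compounds measured in a functional assay for antagonist activity at integrin alpha-5/beta-1 (Homo sapiens), read by ELISA; a higher number here means a weaker inhibitor, a lower number a stronger inhibitor: compound 2 gives 18 nM, whereas compound 1 `Cc1cc(C)c(S(=O)(=O)N[C@@H](CNC(=O)C2=NO[C@]3(CN[C@H](CNc4ncc[nH]4)C3)C2)C(=O)O)c(C)c1` gives 230 nM. The only difference between them is a benzyloxycarbonyl group in place of hydrogen on an amine nitrogen in a ring, and that single change produced a 13-fold lower number from compound 1 to compound 2 (1.11 log units; beyond the scatter).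

Compound 3 `CCCCOC(=O)N1C[C@@]2(CC(C(=O)NC[C@H](NS(=O)(=O)c3c(C)cc(C)cc3C)C(=O)O)=NO2)C[C@H]1CNc1ncc[nH]1` keeps the carbamate on that ring nitrogen and alters only its outer end: propyl in place of phenyl on a saturated chain carbon bound to an oxygen next to a carbonyl group. Cut one bond further out, this reads as benzyloxycarbonyl becoming butoxycarbonyl.

Going by the values given here, only one measured step touches this part of the molecule, the large gain on adding the whole benzyloxycarbonyl group, and no measured pair separates the aromatic ring from the rest of that group. Because the carbamate that carried a 13-fold lower number from compound 1 to compound 2 (1.11 log units; beyond the scatter) is retained, most of that gain is expected to persist, with room for a modest drift toward a higher number. For compound 3 the expected step is therefore small, a 1.7-fold higher number from compound 2 to compound 3 (0.22 log units; within the scatter). Compound 3 is estimated at 30 nM, within a range from 10 nM to 90 nM.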

Compound 3, half-maximal inhibitory concentration: 14 nM
Beside the measured number, compound 3's estimate is 2.1-fold (0.33 log units) above it; measured number inside the range.
By their numbers in this assay, from the lowest: compounds 3 and 2 (each within the scatter of the next); then compound 1.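

Replacing the phenyl with propyl gives a 1.3-fold lower number from compound 2 to compound 3 (0.11 log units; within the scatter) in this assay, so the benzyloxycarbonyl and butoxycarbonyl groups cannot be told apart here, and an aromatic ring at the outer end of the carbamate is not required to keep this level of inhibition. Seen from the unsubstituted ring nitrogen, butoxycarbonyl in place of hydrogen gives a 16-fold lower number from compound 1 to compound 3 (1.22 log units; beyond the scatter), a large step in the same direction as a 13-fold lower number from compound 1 to compound 2 (1.11 log units; beyond the scatter), so across these three compounds the large gain appears with either a ring or an open chain at that outer end. Nothing available explains why either group has this effect.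

These three compounds cannot show whether the gain needs the carbamate itself or would also appear with another group on the same nitrogen. A methoxycarbonyl group, an acetyl group or a plain butyl group there would help separate the short and long forms of the chain from the carbonyl and its oxygen, while a longer chain such as hexyloxycarbonyl would test how far the outer end can extend.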